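Pyridin-2-yl Replacing 3-Chlorophenyl in a Cytotoxicity Series

A few compounds are considered here, and "the series" means these few. Any claim that something is new, unique, unknown or untested is made for them only; others in the source may bear on it.

Measured compounds:
Compound 1 `CCOC(=O)C12C(=O)OCC=C1COC2c1cccc(Cl)c1` gives > 1000000 nM in a functional assay on QGY cells (Homo sapiens) for cytotoxicity, read by MTT assay; on this read-out lower numbers stand for stronger inhibition and higher numbers for weaker inhibition; this value is a limit of the assay.
Compound 2 `CCOC(=O)C12C(=O)OCC=C1COC2c1ccc(Cl)c(Cl)c1` gives > 1000000 nM in this assay; this value is a limit.
Compound 3 `CCOC(=O)C12C(=O)OCC=C1COC2c1cc(OC)c(OC)c(OC)c1` gives > 1000000 nM in this assay; this value is a limit.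

Compound 1 thus stands only at a limit, with no number of its own, and the two further values shown are limits as well (the limit of > 1000000 nM in this assay, at which 3 of the 3 values shown sit). Among the compounds with values here, the one measured step between compounds differing in a single place, chloro in place of hydrogen on an aromatic carbon from compound 1 to compound 2, is a step that the two limits leave unreadable from compound 1 to compound 2, so its size cannot be read.

Compound 4 `CCOC(=O)C12C(=O)OCC=C1COC2c1ccccn1` differs from compound 1 by pyridin-2-yl in place of 3-chlorophenyl on a saturated ring carbon. Within the data shown here, no measured step speaks to this change, and the only step available is itself unreadable. It is therefore expected that compound 4 also reaches only the limit, so the expected step from compound 1 to compound 4 is a number no higher from compound 1 to compound 4 (the limit leaves the size open). The estimate for compound 4 is 1000000 nM, with a range from 200000 nM to 5000000 nM.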

Compound 4, half-maximal inhibitory concentration: > 1000000 nM
Compound 4 gave a limit, no number; the forecaster's own chance of this, stated with the estimate: 85%; the middle value lies on the limit itself.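

Compound 4 and compound 1 both stand only at a limit, so the step between them, pyridin-2-yl in place of 3-chlorophenyl, cannot be read: the limit of > 1000000 nM in this assay, at which 4 of the 4 values shown sit. The compounds shown leave open what change to the shared core, if any, would give a measurable number in this assay.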